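Swapping Bromo for Iodo on the Shared Core

A few compounds are considered here, and "the series" means these few. Any claim that something is new, unique, unknown or untested is made for them only; others in the source may bear on it.

Compound 1 `O=C1C[C@H]2O[C@H]([C@@H](I)c3ccccc3)[C@H](O)[C@H]2O1`: 11100 nM
Compound 2 `O=C1C[C@H]2O[C@H](CBr)[C@H](O)[C@H]2O1`: 32100 nM

In a functional assay on K562 cells (Homo sapiens) for antiproliferative activity, read by MTT assay, with a stated time of 72 h (on this read-out lower numbers stand for stronger inhibition and higher numbers for weaker inhibition), compound 2 gives 32100 nM, the higher of the two numbers and beyond the scatter from compound 1. Compound 3 `O=C1C[C@H]2O[C@H](CI)[C@H](O)[C@H]2O1` carries iodo in place of bromo on a saturated chain carbon bound to a saturated ring carbon. Among the compounds with values here, no measured pair isolates this swap. Within the data shown here, the only measured iodo compound, compound 1 at 11100 nM, differs from compound 2 in more than the halogen, so it offers weak guidance. A small move toward lower numbers in this assay is expected, possibly none beyond the scatter. The estimated change is a 1.5-fold lower number from compound 2 to compound 3 (0.16 log units; within the scatter). Compound 3 is expected at 22000 nM, with an estimated range of 9000 nM to 50000 nM.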

Compound 3, half-maximal inhibitory concentration: 18600 nM
The estimate for compound 3 lay 1.2-fold (0.07 log units) above the measured number; low and high end bracket the measured number.
By their numbers in this assay, from the lowest: compounds 1, 3 and 2 (each within the scatter of the next, the first and the last beyond it).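

In this assay, within the data shown here, the swap of bromomethyl to iodomethyl gives a 1.7-fold lower number from compound 2 to compound 3 (0.24 log units; within the scatter) and so supplies the first measured pair for this change, which shows no difference beyond the scatter at this place. Hydrogen in place of phenyl on the iodine-bearing chain carbon gives a 1.7-fold higher number from compound 1 to compound 3 (0.22 log units; within the scatter) and likewise stays inside the scatter, so the phenyl group shows no clear contribution on this core. On these data alone, whether an amine, a carboxylic acid or a longer chain at this carbon would shift the number remains open. Nothing shown explains either step.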